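The compounds below may be only part of what the source reports. "The series", "measured", "known", "first", "only" and "open" are said of these compounds alone.

Three compounds have been measured:
compound 1, `CCn1c(C(=O)NCCN)ccc1C(CC)(CC)c1ccc(OCCC(O)(CC)CC)c(C)c1`: 156 nM
compound 2, `CCn1c(C(=O)Nc2cccc(C(F)(F)F)c2)ccc1C(CC)(CC)c1ccc(OCCC(O)(CC)CC)c(C)c1`: 5900 nM
compound 3, `CCn1c(C(=O)N(C)CC(=O)O)ccc1C(CC)(CC)c1ccc(OCCC(O)(CC)CC)c(C)c1`: 89 nM

All three share the same core and differ only in the group on the amide. In an assay on cells for agonist activity at vitamin D3 receptor (Homo sapiens), with a stated time of 96 h (a higher number here means that more compound is needed for the effect, a lower number that less compound is needed), compound 1 gives 156 nM, the second highest of the three numbers; the nearest is compound 3 with 89 nM, and the furthest is compound 2 with 5900 nM.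

Compound 4, `CCn1c(C(=O)NC(CC(=O)O)C(=O)OC)ccc1C(CC)(CC)c1ccc(OCCC(O)(CC)CC)c(C)c1`, has not yet been measured. It differs from compound 1 in one place: a group of 9 heavy atoms (5 carbon, 4 oxygen; no ring) in place of a group of 3 heavy atoms (2 carbon, 1 nitrogen; no ring), on an amide-type nitrogen. Going by the values given here, two measured steps bear on this. Putting a 3-(trifluoromethyl)phenyl group on the amide nitrogen gave a 38-fold higher number from compound 1 to compound 2 (1.58 log units; beyond the scatter), whereas putting a (carboxymethyl)(methyl)amino group on the carbonyl carbon gave a 1.8-fold lower number from compound 1 to compound 3 (0.24 log units; within the scatter). The group entering in compound 4 has no ring and, like the change seen in compound 3, carries a carboxylic acid, so it resembles the change toward compound 3 far more than the change toward compound 2. The expected step is therefore small, a 1.0-fold lower number from compound 1 to compound 4 (0.02 log units; within the scatter), with no change beyond the scatter. Compound 4 is estimated at 150 nM, within a range of 50 nM to 500 nM.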

Compound 4, half-maximal effective concentration: 26 nM
For compound 4 the middle estimate is 5.8-fold (0.76 log units) above the measured one; measured number outside the range, below it.
By their numbers in this assay, from the lowest: compound 4; then compounds 3 and 1 (each within the scatter of the next); then compound 2.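

On the amide-type nitrogen, the group in compound 4 does something the earlier replacements did not: in this assay it gives a 6.0-fold lower number from compound 1 to compound 4 (0.78 log units; beyond the scatter) and so moves the number down by more than the scatter, where the group in compound 3 stayed within the scatter and the 3-(trifluoromethyl)phenyl group in compound 2 raised it. A carboxylic acid on a ringless group is therefore not enough to fix the number at this position, as there is a 3.4-fold lower number from compound 3 to compound 4 (0.53 log units; beyond the scatter) even though both compounds carry one, and the spread among the groups tried here now reaches a 230-fold lower number from compound 2 to compound 4 (2.36 log units; beyond the scatter) in the same assay. Nothing shown gives a reason for these differences.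

The group in compound 4 holds both a carboxylic acid and a methyl ester, and it keeps the amide hydrogen that compound 3 lacks, so the compounds shown cannot say which of these features goes with the lower number. A second carboxylic acid in place of the methyl ester, or a longer chain carrying the carboxylic acid, would help to separate these features.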